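The compounds below may be only part of what the source reports. "The series", "measured", "known", "first", "only" and "open" are said of these compounds alone.

Measured compounds:
Compound 1, `COc1ccc(C(=O)/C=C/c2ccc(OC)c(OC)c2OC)c(O)c1`, gives 98.5% in an ADME assay on RAW264.7 cells (Mus musculus) for cytotoxicity, read by MTT assay, with a stated time of 24 h, tested at 1.25 ug/mL; a lower number here means a stronger effect, a higher number a weaker effect of the compound at the concentration tested.
Compound 2, `COc1ccc(C(=O)/C=C/c2cccc(OC)c2OC)c(O)c1`, gives 94.2% in this assay.
Compound 3, `COc1ccc(C(=O)CCc2ccc(OC)c(OC)c2)c(O)c1`, gives 91.8% in this assay.

All three compounds share the pattern of two aromatic rings joined through a carbonyl-bearing linker, and all three leave most of the cells alive in this assay, so the readings sit close together. Compound 1 and compound 2 differ in one place only: hydrogen in place of methoxy on an aromatic carbon. The step that goes with this change is a number 4.3 percentage points lower from compound 1 to compound 2 (within the scatter), so removing the methoxy group left the read-out essentially unchanged. Compound 3 stands on a different core, with a saturated linker in place of the double bond; how the core of compound 3 differs from that of compound 1 is not broken down here, and the two values are within the scatter of each other.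

Compound 4, `COc1ccc(CCC(=O)c2ccc(OC)cc2O)cc1`, has not yet been measured. It arises from compound 3 by the same kind of change seen from compound 1 to compound 2: hydrogen in place of methoxy on an aromatic carbon. The surroundings are not identical, since in compound 1 the leaving methoxy group is also meta to a methoxy group and para to a large group, whereas in compound 3 it is meta to a large group. Because the earlier step of a number 4.3 percentage points lower from compound 1 to compound 2 (within the scatter) stayed within the scatter, the step from compound 3 to compound 4 is expected to be small as well, about a number 2.8 percentage points lower from compound 3 to compound 4 (within the scatter). Compound 4 is therefore estimated to give 89% in this assay, with a range from 80% to 98%.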

Compound 4, a percentage reported as activity, at one concentration (the size of the read-out at that concentration, not a potency): 95.1%
The estimate for compound 4 lay 6.1 percentage points below the measured number; the range from low to high includes it.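

On the core of compound 3, the step that goes with hydrogen in place of methoxy on an aromatic carbon in this assay is a number 3.3 percentage points higher from compound 3 to compound 4 (within the scatter), and the step seen earlier on the other core agrees with it as far as this read-out can tell: the same change on two cores in this assay, a number 4.3 percentage points lower (within the scatter) from compound 1 to compound 2 and a number 3.3 percentage points higher (within the scatter) from compound 3 to compound 4, 7.6 percentage points apart, within the scatter of two such steps

So in the two pairs available, the change carries from one core to the other as a small step, and the fact that one number goes down while the other goes up should not be read as a real difference between the cores. This does not show that the methoxy group is without any effect in general, or that the change would stay this small on every core in the series, since it rests on just two pairs, in surroundings that are not identical, at a single concentration that gives no potency.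

The compounds shown leave open what would happen if an amine, a carboxylic acid or a longer chain such as ethoxy stood on that aromatic carbon instead of methoxy or hydrogen. They also leave open whether the two steps would remain this small at other concentrations, where the cells might respond more strongly.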